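Replacing an aromatic tail with isobutyl, without a baseline

The source may report more compounds than this note shows. Statements on the series, on what has been measured and on what is new or still open speak of the compounds shown alone.

This small series has one read-out, an ADME assay on J774.A1 cells (Mus musculus) for cytotoxicity, read by MTT assay, with a stated time of 48 h; a lower number here means that less compound is tolerated, a higher number that more compound is tolerated. In that test, compound 1 (`O=C(O)c1c([N+](=O)[O-])noc1-c1ccc([N+](=O)[O-])cc1`) gives "not determined" (no result reported). Going by the values given here, compound 2 (`COc1ccc(CNC(=O)c2c([N+](=O)[O-])noc2-c2ccc([N+](=O)[O-])cc2)cc1`) gives 69600 nM, the only actual number so far. Compound 3 (`COc1cccc(CNC(=O)c2c([N+](=O)[O-])noc2-c2ccc([N+](=O)[O-])cc2)c1`) gives "not determined" (no result reported), so it has no place on the scale and cannot serve as a starting point for a comparison.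

Compound 4 (`CC(C)CCNC(=O)c1c([N+](=O)[O-])noc1-c1ccc([N+](=O)[O-])cc1`) has yet to be tested. The change isobutyl in place of 3-methoxyphenyl on a saturated chain carbon bound to an amide-type nitrogen puts isobutyl in place of 3-methoxyphenyl on a saturated chain carbon bound to an amide-type nitrogen, while the shared core stays the same. Among the compounds with values here, no measured step shows how far such a swap can move the result.

The closest reference is therefore compound 2 at 69600 nM, which shares that core. Measured against this single anchor in this assay, the expected step is none beyond the usual scatter, with no firm direction. One number is thin support, so the range has to stay wide. The expected value for compound 4 is 60000 nM, with an estimated range from 20000 nM to 150000 nM.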

Compound 4, half-maximal cytotoxic concentration: 67000 nM
Estimate against measurement, compound 4: 1.1-fold (0.05 log units) below; measured number inside the range.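

In this assay, going by these compounds alone, the swap gives a 1.0-fold lower number from compound 2 to compound 4 (0.02 log units; within the scatter), which makes this the first comparison at this position that can be read at all. For this one pair, a tail without a ring and without a methoxy oxygen cannot be told apart from a 4-methoxyphenyl tail on the same saturated chain carbon, so the aromatic ring is not needed for the number to fall at this level. The step from compound 3 cannot be read, as compound 3 has no number, and nothing shown here offers an explanation for the match between compound 2 and compound 4.

As far as these compounds go, whether an amine at the end of the chain, or a chain longer than isopentyl, would also stay level with compound 2 remains open. From the compounds shown here alone, it is also open whether this match is general or belongs only to these two tails, as a single pair cannot separate the two cases.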